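Anilino-thiazole ketones: methoxy for fluoro on the anilino ring

A few compounds are considered here, and "the series" means these few. Any claim that something is new, unique, unknown or untested is made for them only; others in the source may bear on it.

Measured compounds in a functional assay on CCRF-CEM cells (Homo sapiens) for antiproliferative activity, read by cell counting, with a stated time of 2 days; a lower number here means a stronger inhibitor, a higher number a weaker inhibitor:
- compound 1 `COc1ccc(C(=O)c2sc(Nc3ccc(F)cc3)nc2N)cc1`: > 10000 nM, a limit of the assay
- compound 2 `Nc1nc(Nc2ccc(F)cc2)sc1C(=O)c1ccccc1`: > 10000 nM, a limit of the assay
- compound 3 `COc1cc(C(=O)c2sc(Nc3ccc(Cl)cc3)nc2N)cc(OC)c1OC`: 190 nM

Compound 2 stands at the limit of this assay, so only a lower bound on its potency is known. Compound 1 sits at the same limit, and the step that the two limits leave unreadable from compound 1 to compound 2 is therefore unreadable; the shared limit is described by the limit of > 10000 nM in this assay, at which 2 of the 3 values shown sit. Among the compounds with values here, compound 3 gives a numerical value, but it differs from compound 2 in more than one place, so no single step to it can be read.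

The next compound, compound 4 `COc1ccc(Nc2nc(N)c(C(=O)c3ccccc3)s2)cc1`, carries the change (methoxy in place of fluoro on an aromatic carbon), on an aromatic carbon of a six-membered aromatic ring of carbon only, para to a large group. Within the data shown here, no measured step bears directly on this change, and the only step of comparable kind, from compound 1 to compound 2, is unreadable between two limits. The expectation for this assay is therefore a step that the limit leaves unreadable from compound 2 to compound 4 of no size that can be read, with compound 4 most likely remaining at the limit. Compound 4 is estimated at 15000 nM, within 3000 nM to 60000 nM.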

Compound 4, half-maximal inhibitory concentration: 300 nM
Compound 4: middle estimate off by 50-fold (1.70 log units), on the high side; measured number outside the range, below it.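

In this assay, this position now has a readable effect: methoxy in place of fluoro on an aromatic carbon, para to a large group, gives an at least 33-fold lower number from compound 2 to compound 4 (1.52 log units; beyond the scatter). The earlier pair, compound 1 and compound 2, gave no readable step, whereas this change shows that the group at this place can take a compound off the limit. The size of the step is itself only a bound, since compound 2 is held at a limit: the limit of > 10000 nM in this assay, at which 2 of the 4 values shown sit.

On these data alone, whether the gain is particular to methoxy stays open, and how ethoxy, hydroxy or dimethylamino at this place would compare is unknown. Compound 3 differs from compound 4 in more than one place, so its chloro group cannot be set directly against methoxy.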